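A few compounds are considered here, and "the series" means these few. Any claim that something is new, unique, unknown or untested is made for them only; others in the source may bear on it.

Measured compounds:
- Compound 1 `CC1=NN(c2ccc(C)cc2)C(=O)C12C=CC(=O)C=C2c1ccc(C)cc1` — 37000 nM
- Compound 2 `CC1=NN(c2ccccc2)C(=O)C12C=CC(=O)C=C2c1ccccc1` — 16500 nM

In a functional assay on A549 cells (Homo sapiens) for antiproliferative activity, read by CCK-8 assay, with a stated time of 72 h (on this read-out higher numbers stand for weaker inhibition and lower numbers for stronger inhibition), compound 2 gives 16500 nM, the lowest of the two numbers available. Among the measured compounds shown here, its nearest neighbour is compound 1, which in this assay gives 37000 nM, a higher number that lies beyond the usual scatter; the two compounds differ in more than one place, so the comparison says only that compound 2 inhibits growth more strongly. Compound 3 `CC1=NN(c2cccc(Cl)c2)C(=O)C12C=CC(=O)C=C2c1ccccc1` has not yet been measured in this assay. It differs from compound 2 by chloro in place of hydrogen on an aromatic carbon. For the measured compounds named here, no step between measured compounds covers such a change, so there is no basis for predicting a large shift; a modest gain or a result within the scatter is expected. Compound 3 is estimated at 12000 nM, with a range of 4000 nM to 40000 nM, meaning an expected step of a 1.4-fold lower number from compound 2 to compound 3 (0.14 log units; within the scatter).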

Compound 3, half-maximal inhibitory concentration: 18800 nM
Beside the measured number, compound 3's estimate is 1.6-fold (0.19 log units) below it; the range from low to high includes it.
By their numbers in this assay, from the lowest: compounds 2, 3 and 1 (each within the scatter of the next, the first and the last beyond it).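

Among the compounds shown here, the change from phenyl to 3-chlorophenyl is the first change in a single place that can be read in this assay, and it amounts to a 1.1-fold higher number from compound 2 to compound 3 (0.06 log units; within the scatter). At this aromatic carbon, chloro in place of hydrogen therefore leaves the number within the scatter, something the earlier pair of compounds, which differ in more than one place, could not show. No measurement at hand accounts for this result.

On these data alone, whether a different group on this carbon, such as an amine, a methoxy group or a carboxylic acid, would move the number beyond the scatter remains open. As far as these compounds go, it is also open whether chloro would give the same result on another carbon of this ring or on the second phenyl ring.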